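Swapping the Aryl Group on Compound 1

The compounds below may be only part of what the source reports. "The series", "measured", "known", "first", "only" and "open" are said of these compounds alone.

- compound 1 `COc1cc(CNCc2ccncc2)ccc1OCc1ccc(F)cc1`: 6400 nM
- compound 2 `COc1cc(CNCCSc2nnnn2C)ccc1OCc1ccc(Cl)nc1`: 86000 nM
- compound 3 `COc1cc(CNCc2cccnc2)ccc1OCc1ccc(Cl)nc1`: 5000 nM

All three values come from a functional assay on HeLa cells (Homo sapiens) for inhibition, with a stated time of 72 h; a higher number here means that more compound is needed for the effect, a lower number that less compound is needed. Compound 1 stands with compound 3 at the low end of this small set, the two values lying within the usual scatter of each other, while compound 2 lies far higher.

The next compound is compound 4 `COc1cc(CNCc2ccncc2)ccc1OCc1cnc(Cl)c(Cl)c1`, which keeps the amine side of compound 1 and changes the other end of the molecule: 5,6-dichloropyridin-3-yl in place of 4-fluorophenyl on a saturated chain carbon bound to an oxygen on an aromatic ring. In words, 5,6-dichloropyridin-3-yl stands in place of 4-fluorophenyl on a saturated chain carbon bound to an oxygen on an aromatic ring.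

For the measured compounds named here, the only measured step, a 17-fold lower number from compound 2 to compound 3 (1.24 log units; beyond the scatter), is a change on the amine side, so it says nothing direct about this swap. Going by the values given here, no measured pair isolates the new change. The nearest hint is compound 3, which also has a chlorine-bearing pyridine ring at that end and gives 5000 nM, although it differs from compound 1 on the amine side too.

No shift beyond the scatter is therefore expected in this assay, though this rests on thin evidence. The expected step is a 1.4-fold lower number from compound 1 to compound 4 (0.15 log units; within the scatter). For compound 4 the estimated value is 4500 nM, with an expected range from 1500 nM to 14000 nM.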

Compound 4, half-maximal effective concentration: 220 nM
The estimate for compound 4 lay 20-fold (1.31 log units) above the measured number, outside the stated range (below it).
By their numbers in this assay, from the lowest: compound 4; then compounds 3 and 1 (each within the scatter of the next); then compound 2.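

The group on the saturated chain carbon bound to an oxygen on an aromatic ring matters a great deal in this assay: placing 5,6-dichloropyridin-3-yl there instead of 4-fluorophenyl gives a 29-fold lower number from compound 1 to compound 4 (1.46 log units; beyond the scatter) with the amine side held fixed. For the compounds shown here, until now, the only step beyond the scatter lay on the amine side, so this is the first sign that the other end of the molecule can also move the number strongly. Nothing measured here explains the step, and it remains unknown what lies behind it.

The swap brings in the ring nitrogen and both chlorines together, so the compounds shown cannot tell which of these changes carries the step; a dichlorophenyl ring or an unsubstituted pyridine ring at this place would begin to separate them. From the compounds shown here alone, whether 5,6-dichloropyridin-3-yl gives a step of similar size with a different amine side, such as the chain with the methyl tetrazole in compound 2, also remains open.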